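Methoxy in Place of Hydrogen: What to Expect for Compound 4

A few compounds are considered here, and "the series" means these few. Any claim that something is new, unique, unknown or untested is made for them only; others in the source may bear on it.

Compound 1 `COc1ccc(/C=C2\CCC3=CC(=O)CCC3(C)C2=O)cc1` gives 6000 nM in a functional assay on B16 cells (Mus musculus) for inhibition, with a stated time of 3 days; a higher number here means a weaker inhibitor, a lower number a stronger inhibitor.
Compound 2 `CC1CCC/C(=C\c2ccccc2)C1=O` gives > 30000 nM in this assay, which is a limit of the assay and not a number.
Compound 3 `CC1CCC/C(=C\c2ccc(Cl)cc2)C1=O` gives > 30000 nM in this assay, again a limit of the assay.

Compound 2 therefore stands only at a limit in this assay; of the three values shown, two sit at that limit (the limit of > 30000 nM in this assay, at which 2 of the 3 values shown sit), and only compound 1 has a number. Compound 4 `COc1ccc(/C=C2\CCCC(C)C2=O)cc1` differs from compound 2 in one place: methoxy in place of hydrogen on an aromatic carbon. Within the data shown here, the one measured step on the same core, a step that the two limits leave unreadable from compound 2 to compound 3, runs from one limit to another and its size cannot be read. Among the measured compounds shown here, compound 1 carries the same methoxy group on a different core, and no step to it is measured, so its value says nothing direct about the change. With no readable step to lean on, no move beyond the scatter is expected, and the estimate for compound 4 is 30000 nM, within 8000 nM to 100000 nM, with a step of a number no higher from compound 2 to compound 4 (the limit leaves the size open) expected from compound 2, most likely ending again at a limit.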

Compound 4, half-maximal inhibitory concentration: > 30000 nM
Compound 4: a limit, no number; the forecaster's own chance of this, stated with the estimate: 65%; the middle value sits exactly at the limit.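

Compound 2, compound 3 and compound 4 all stand at a limit and not at a number, so no step among them can be read: the limit of > 30000 nM in this assay, at which 3 of the 4 values shown sit.

The compounds shown leave open whether methoxy or chloro in place of hydrogen on the aromatic carbon changes inhibition on the shared core at all.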